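Alkoxy chain length on a pyrazole amide core

The source may hold more compounds than are shown below. What is called first, only, known or untested is meant among the compounds shown, and "the series" means these compounds.

Compounds measured so far:
compound 1 `COc1cc(C(=O)N2CCCC2)nn1-c1ccccc1`: 29.2%
compound 2 `CCCOc1cc(C(=O)N(C)C)nn1-c1ccccc1`: 26.2%
compound 3 `CC(C)Oc1cc(C(=O)N(C)C)nn1-c1ccccc1`: 43.9%

In a functional assay on the whole organism (strain Wistar) for inhibition, with Rattus norvegicus as the target, read by paw edema, with stated times of 30 min and 3 h, at a dose of 100 mg/kg by the oral route (on this read-out higher numbers stand for more inhibition at the one dose given (going by the name of the read-out) and lower numbers for less inhibition), compound 3 gives the highest of the three numbers, with compound 1 nearest and compound 2 furthest, both beyond the scatter. Compound 4 `CCCCOc1cc(C(=O)N(C)C)nn1-c1ccccc1` differs from compound 3 by butyl in place of isopropyl on an oxygen on an aromatic ring. Among the compounds with values here, the one measured step that bears on it is a number 17.7 percentage points higher from compound 2 to compound 3 (beyond the scatter), which links a straight chain to a branched one at the same oxygen. Within the data shown here, compound 4 returns to a straight chain, one carbon longer than in compound 2, so a step back toward the number of compound 2 is expected, though no measured step covers the added carbon. Compound 4 is therefore estimated at 30%, between 15% and 45%, a step of a number 13.9 percentage points lower from compound 3 to compound 4 (beyond the scatter) expected from compound 3.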

Compound 4, a percentage reported as inhibition, in the whole organism at one dose (the size of the read-out at that dose, not a potency): 18.7%
Compound 4: middle estimate off by 11.3 percentage points, on the high side; the measured number falls inside the stated range.
By their numbers in this assay, from the lowest: compounds 4, 2 and 1 (each within the scatter of the next, the first and the last beyond it); then compound 3.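

In this assay, butyl in place of isopropyl gives a number 25.2 percentage points lower from compound 3 to compound 4 (beyond the scatter) and so sets the branched isopropyl on this oxygen apart from a second straight chain, not only from propyl. Going from propyl to butyl gives a number 7.5 percentage points lower from compound 2 to compound 4 (within the scatter), so the added methyl on the chain has no readable effect here. No evidence at hand accounts for the difference between the branched and straight chains. The compounds shown leave open whether a tert-butyl or cyclopentyl group on this oxygen would match compound 3, and whether a longer chain such as hexyl would stay level with compound 4.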